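Adding an Acetamido Group to Compound 1

The source may hold more compounds than are shown below. What is called first, only, known or untested is meant among the compounds shown, and "the series" means these compounds.

Compound 1 `COc1cc2ccc(=O)oc2cc1OCCOc1no[n+]([O-])c1S(=O)(=O)c1ccccc1` was tested in a functional assay on A549 cells (Homo sapiens) for inhibition, read by MTT assay, with a stated time of 48 h (a lower number here means a stronger inhibitor, a higher number a weaker inhibitor), where compound 1 gives 7240 nM. Its companion, compound 2 `COc1cc2ccc(=O)oc2cc1OCCCCCCOc1c[n+]([O-])on1`, gives in this assay a value of 9430 nM. Compound 1 has the lowest of the two numbers, but the gap to compound 2 lies within the scatter, so the two cannot be told apart on these data.

Compound 3 `COc1cc2cc(NC(C)=O)c(=O)oc2cc1OCCOc1no[n+]([O-])c1S(=O)(=O)c1ccccc1` has not yet been measured in this assay. It differs from compound 1 in one place: acetamido in place of hydrogen on an aromatic carbon. Among the compounds with values here, no measured pair in this set shows such a change, so nothing here shows how large a step it brings. Within the data shown here, with only two values in hand, both of them weak and indistinguishable, the expected step is small, and no direction can be read from compound 1 at 7240 nM or compound 2 at 9430 nM.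

Compound 3 is therefore expected to give about 6000 nM, within a range from 2000 nM to 18000 nM. This estimate corresponds to an expected step of a 1.2-fold lower number from compound 1 to compound 3 (0.08 log units; within the scatter).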

Compound 3, half-maximal inhibitory concentration: 8790 nM
Compound 3: middle estimate off by 1.5-fold (0.17 log units), on the low side; the measured number falls inside the stated range.
By their numbers in this assay, from the lowest: compounds 1, 3 and 2 (each within the scatter of the next).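

In this assay, within the data shown here, acetamido in place of hydrogen on the aromatic carbon two atoms from the ring oxygen gives a 1.2-fold higher number from compound 1 to compound 3 (0.08 log units; within the scatter) and so provides the first step in this set that can be read at this position. The position therefore takes acetamido without any change that can be separated from the usual scatter, and neither a gain nor a loss can be claimed for this replacement on the core of compound 1. No evidence is available that bears on this result, so the data cannot say why the number stays where it does.

With only this one replacement shown at the position, it remains open whether a free amine, a carboxylic acid or a longer acyl chain on the same carbon would move the number beyond the scatter, or whether any group placed here can do so. Going by these compounds, compound 2 differs from compound 1 and compound 3 in more than one place, so steps to it cannot be read, and the effect of acetamido on the core of compound 2 also remains open.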